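The source may hold more compounds than are shown below. What is called first, only, known or untested is meant among the compounds shown, and "the series" means these compounds.

In a functional assay on MOLT-4F cells (Homo sapiens) for antiproliferative activity (a higher number here means a weaker inhibitor of growth, a lower number a stronger inhibitor of growth), compound 1 `COCCCCCCCCCCCCCCC/C=C1/CC(CO)(COC(=O)C(C)(C)C)OC1=O` gives 1.64 ug/mL and compound 3 `CCCCCOCCCCCCC/C=C1\CC(CO)(COC(=O)C(C)(C)C)OC1=O` gives 1.03 ug/mL, two values within the scatter of each other. Compound 2 `CCCCCCCCC(O)CCCCCC/C=C1\CC(CO)(COC(=O)C(C)(C)C)OC1=O` gives 7.91 ug/mL. Compound 4 `CC(=O)OCCCCCCCCCCCCCCC/C=C1\CC(CO)(COC(=O)C(C)(C)C)OC1=O` differs from compound 3 by 8-acetoxyoctyl in place of pentyloxy on a saturated chain carbon, seven bonds along the chain from a double-bonded chain carbon, with 8-acetoxyoctyl in place of pentyloxy on a saturated chain carbon, seven bonds along the chain from a double-bonded chain carbon. Going by the values given here, only one measured step also alters this chain, a 7.7-fold lower number from compound 2 to compound 3 (0.89 log units; beyond the scatter), and it shows that such a swap can matter. It is a different swap, however, so a smaller rise in this assay is expected. The expected change is a 1.9-fold higher number from compound 3 to compound 4 (0.29 log units; within the scatter). For compound 4, the estimated value is 2 ug/mL, with an expected range of 0.7 ug/mL to 6 ug/mL.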

Compound 4, concentration for 50% growth inhibition: 1.55 ug/mL
Compound 4: middle estimate off by 1.3-fold (0.11 log units), on the high side; the range from low to high includes it.
By their numbers in this assay, from the lowest: compounds 3, 4 and 1 (each within the scatter of the next); then compound 2.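

In this assay, 8-acetoxyoctyl in place of pentyloxy gives a 1.5-fold higher number from compound 3 to compound 4 (0.18 log units; within the scatter). This place on the chain therefore accepts a group of 12 heavy atoms instead of 6, with an added acetoxy end, without a change that can be told from the scatter, so not every swap in this chain matters as much as a 7.7-fold lower number from compound 2 to compound 3 (0.89 log units; beyond the scatter). No measurement shown accounts for this result. On these data alone, it remains open whether an amine or a carboxylic acid in this same place would be accepted as well. A single swap also cannot show how far the group can grow, so a longer chain could still behave differently.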